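Replacing Ethyl with Trimethoxyphenyl on the Shared Core

The source may hold more compounds than are shown below. What is called first, only, known or untested is meant among the compounds shown, and "the series" means these compounds.

Compound 1 `CCc1nnc(SCc2ccccc2)n1N1C(=O)c2ccccc2C1=O` is measured in a functional assay on MKN-45 cells (Homo sapiens) for cytotoxicity, read by MTT assay, with a stated time of 48 h; a higher number here means a weaker inhibitor, a lower number a stronger inhibitor. In this assay compound 1 gives only a limit, > 200000 nM. The same holds for compound 2 `CCc1nnc(SCC(=O)c2ccccc2)n1N1C(=O)c2ccccc2C1=O`, which in this assay reaches only the limit > 200000 nM. Compound 3 `CCc1nnc(SCC(=O)c2ccc(C)cc2)n1N1C(=O)c2ccccc2C1=O` likewise gives only the limit > 200000 nM in this assay. Accordingly the step that the two limits leave unreadable from compound 1 to compound 2, the step that the two limits leave unreadable from compound 1 to compound 3 and the step that the two limits leave unreadable from compound 2 to compound 3 are all unreadable in size, and the one fact on record is the limit of > 200000 nM in this assay, at which 3 of the 3 values shown sit. Going by the values given here, compound 1 therefore stands at the limit of this assay, and no measured compound supplies a number against which it could be placed.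

Compound 4 `COc1cc(-c2nnc(SCc3ccccc3)n2N2C(=O)c3ccccc3C2=O)cc(OC)c1OC` differs from compound 1 by 3,4,5-trimethoxyphenyl in place of ethyl on an aromatic carbon. Among the compounds with values here, none of the measured steps touches this position or this kind of group, and all three leave the size of their change unreadable. Within the data shown here, there is thus no measured step from which a direction or a size for the step in this assay can be drawn. The expectation for compound 4 is that it stays close to the limit: compound 4 is estimated at 150000 nM, within 30000 nM to 400000 nM. The step this estimate implies, an at least 1.3-fold lower number from compound 1 to compound 4 (0.12 log units; that floor lies within the scatter), is expected with the understanding that a limit may again be all the assay reports.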

Compound 4, half-maximal inhibitory concentration: > 200000 nM
Compound 4 ended at the assay's limit (the forecaster's own chance of this, stated with the estimate: 60%); at least 1.3-fold (0.12 log units) between middle value and limit.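

In this assay, going by these compounds alone, compound 4 gives > 200000 nM, which is a limit and not a number, so no step from compound 1 to compound 4 can be read. The compounds shown leave open how far each lies past the limit and whether 3,4,5-trimethoxyphenyl in place of ethyl changes the result at all.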